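Replacing the 3-chlorophenyl group of compound 2

The source may report more compounds than this note shows. Statements on the series, on what has been measured and on what is new or still open speak of the compounds shown alone.

In a functional assay on A549 cells (Homo sapiens) for antiproliferative activity, read by MTT assay, with a stated time of 24 h (on this read-out higher numbers stand for weaker inhibition and lower numbers for stronger inhibition), compound 1 `O=C(NNc1ccccc1Cl)c1ccc(NS(=O)(=O)c2cnc(O)nc2O)cc1` gives 3340 nM and compound 2 `O=C(NNc1cccc(Cl)c1)c1ccc(NS(=O)(=O)c2cnc(O)nc2O)cc1` gives 7290 nM. Compound 2 therefore has the higher of these two numbers, which means weaker inhibition. The two compounds differ only in their chlorophenyl group, and the measured change is a 2.2-fold higher number from compound 1 to compound 2 (0.34 log units; beyond the scatter). Compound 3 `Cc1ccccc1NNC(=O)c1ccccc1NS(=O)(=O)c1cnc(O)nc1O` reads > 20000 nM, which is a limit of the assay and not a number.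

The next compound, compound 4 `Cc1ccccc1C(=O)NNC(=O)c1ccc(NS(=O)(=O)c2cnc(O)nc2O)cc1`, carries (2-methylphenyl)carbonyl in place of 3-chlorophenyl on an amine nitrogen. This is a larger edit than swapping one chlorophenyl group for another, since a carbonyl now joins the ring to the amine nitrogen. Within the data shown here, only one measured step bears on it, the modest 2.2-fold higher number from compound 1 to compound 2 (0.34 log units; beyond the scatter), and that step does not test a carbonyl at this place. With so little guidance, no step beyond the usual scatter is expected in this assay, though the uncertainty is wide in both directions. The expected change is a 1.2-fold higher number from compound 2 to compound 4 (0.09 log units; within the scatter). For compound 4 the estimated value is 9000 nM, with an expected range from 3000 nM to 20000 nM.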

Compound 4, half-maximal inhibitory concentration: 15100 nM
Compound 4: middle estimate off by 1.7-fold (0.22 log units), on the low side, within the range that was stated.
By their numbers in this assay, from the lowest: compound 1; then compound 2; then compound 4. At a limit, above all of these: compound 3.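

Until now, this amine nitrogen had only been compared across two chlorophenyl groups, so the effect of joining the ring through a carbonyl was unknown. In this assay, (2-methylphenyl)carbonyl in place of 3-chlorophenyl gives a 2.1-fold higher number from compound 2 to compound 4 (0.32 log units; beyond the scatter), and in place of 2-chlorophenyl it gives a 4.5-fold higher number from compound 1 to compound 4 (0.66 log units; beyond the scatter), so both chlorophenyl compounds inhibit more strongly than the carbonyl-linked compound, and the larger step is the one starting from the 2-chlorophenyl group. Even so, the carbonyl-linked compound still gives a measured number, whereas compound 3 is recorded only as a limit of the assay and not as a number: the limit of > 20000 nM in this assay, at which 1 of the 4 values shown sits.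

The ring, its methyl group and its carbonyl link all differ together in this single change, and the compounds shown do not separate their contributions. A plain benzoyl group at this place would isolate the role of the methyl group, while an acetyl group, which has a carbonyl but no ring, would help show how much of the step belongs to the carbonyl and how much to the ring.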